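This account rests on a few compounds, and the source may have more. Where it says the series, first, only, none or still open, it means among the compounds named here.

Of the compounds shown here, two sharing one core have so far been measured in a functional assay on SW1573 cells (Homo sapiens) for antiproliferative activity, read by sulforhodamine B assay, with a stated time of 48 h; on this read-out higher numbers stand for weaker inhibition of growth and lower numbers for stronger inhibition of growth. Compound 1 `COC(=O)C#CC(O/C=C/C(=O)OC)C(C)C` gives 750 nM in this assay and stands as the lowest of the two numbers. Compound 2 `COC(=O)C#CC(C[C@@H](C)CCC=C(C)C)O/C=C/C(=O)OC` gives 2200 nM in this assay, a gap from compound 1 that lies beyond the usual scatter. Compound 3 `CCCCC(C#CC(=O)OC)O/C=C/C(=O)OC` has not yet been measured. It differs from compound 1 in a single place: butyl in place of isopropyl on a saturated chain carbon bound to an oxygen on an unsaturated carbon and a triple-bonded carbon. Among the measured compounds shown here, both groups, the isopropyl that leaves and the butyl that enters, are small saturated carbon chains, and no measured pair shows this kind of exchange directly, so any expectation rests on compound 1 alone. The step of a 1.2-fold higher number from compound 1 to compound 3 (0.08 log units; within the scatter) is expected to be small, slightly upward at most, and likely within the scatter. Compound 3 is therefore estimated at 900 nM in this assay, with a plausible range from 400 nM to 2000 nM.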

Compound 3, concentration for 50% growth inhibition: 240 nM
Beside the measured number, compound 3's estimate is 3.8-fold (0.57 log units) above it; measured number below the stated range.
By their numbers in this assay, from the lowest: compound 3; then compound 1; then compound 2.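

In this assay, butyl in place of isopropyl on a saturated chain carbon bound to an oxygen on an unsaturated carbon and a triple-bonded carbon gives a 3.1-fold lower number from compound 1 to compound 3 (0.49 log units; beyond the scatter) and so favours the butyl compound. This shows that the position is not indifferent to an exchange between two small saturated carbon chains, even though neither group has a ring, a hydrogen-bond donor or acceptor, or a net charge. No measured finding accounts for this step.

This single pair cannot separate the effect of the butyl chain's length from that of its lack of the isopropyl branch point. It also leaves open whether a longer chain such as hexyl, a phenyl ring or an amine at this place would keep, extend or lose the lower number.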